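The source may report more compounds than this note shows. Statements on the series, on what has been measured and on what is new or still open speak of the compounds shown alone.

Measured so far in a functional assay on A549 cells (Homo sapiens) for inhibition, read by MTT assay, with a stated time of 24 h; on this read-out lower numbers stand for stronger inhibition and higher numbers for weaker inhibition:

Compound 1 `CCOC(=O)C1=Cc2ccccc2OC1(OCc1cc(-c2ccc(Br)cc2)no1)C(F)(F)F` gives > 150000 nM, a limit of the assay.
Compound 2 `O=C(O)C1=Cc2ccccc2OC1(OCc1cc(-c2ccc([N+](=O)[O-])cc2)no1)C(F)(F)F` gives > 150000 nM, a limit of the assay.
Compound 3 `CCOC(=O)C1=Cc2ccccc2OC1(OCc1cc(-c2ccc([N+](=O)[O-])cc2)no1)C(F)(F)F` gives > 150000 nM, a limit of the assay.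

Compound 2 therefore stands only at a limit in this assay, and the two further values shown are limits as well. The step from compound 1 to compound 3 is a step that the two limits leave unreadable from compound 1 to compound 3, and the step from compound 2 to compound 3 is a step that the two limits leave unreadable from compound 2 to compound 3; neither can be read, because of the limit of > 150000 nM in this assay, at which 3 of the 3 values shown sit.

Compound 4 `O=C(O)C1=Cc2ccccc2OC1(OCc1cc(-c2cccc(C(F)(F)F)c2)no1)C(F)(F)F` is not yet measured. It differs from compound 2 by 3-(trifluoromethyl)phenyl in place of 4-nitrophenyl on an aromatic carbon. No measured step touches this change, and the two steps that are shown give no readable size. For the measured compounds named here, on the numbers so far, the expectation for compound 4 is that this assay again reports only a limit, with a number beyond it being the less likely outcome. For compound 4 the estimate therefore means a number no higher from compound 2 to compound 4 (the limit leaves the size open), none beyond the scatter. Compound 4 is expected at 150000 nM, within 80000 nM to 300000 nM.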

Compound 4, half-maximal inhibitory concentration: > 150000 nM
Compound 4: no number, only a limit; the forecaster's own chance of this, stated with the estimate: 85%; the middle value lies on the limit itself.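

In this assay compound 4 gives > 150000 nM, a limit and not a number. No step from compound 2 to compound 4 can be read: the limit of > 150000 nM in this assay, at which 4 of the 4 values shown sit.

The compounds shown leave open whether any change on the shared core gives a measurable inhibition value.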